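A few compounds are considered here, and "the series" means these few. Any claim that something is new, unique, unknown or untested is made for them only; others in the source may bear on it.

Measured so far in a physicochemical assay for solubility, in phosphate buffer, at pH 7.4; a lower number here means a less soluble compound, a higher number a more soluble compound:
- Compound 1 `c1ccc2nc(N3CC(Oc4nccnc4N4CCCCC4)C3)ccc2c1`: < 1000 nM (a limit of the assay, not a number)
- Compound 2 `OCc1cccc(-c2nccnc2OC2CN(c3ccc4ccccc4n3)C2)c1`: 29000 nM

For the measured compounds named here, compound 2 holds the only actual number so far, as the one other result is a limit. Compound 3 `c1ccc(-c2nccnc2OC2CN(c3ccc4ccccc4n3)C2)cc1` has hydrogen in place of hydroxymethyl on an aromatic carbon, so 3-(hydroxymethyl)phenyl becomes phenyl: hydrogen in place of hydroxymethyl on an aromatic carbon.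

Going by the values given here, one measured step bears on this change, a large one in which 3-(hydroxymethyl)phenyl took the place of piperidin-1-yl. Compound 3 keeps the phenyl but not the hydroxymethyl, so part of the rise seen in an at least 29-fold higher number from compound 1 to compound 2 (1.46 log units; beyond the scatter) is expected to be lost. That single step cannot show how much of the rise goes with the hydroxymethyl. The expected step is a 12-fold lower number from compound 2 to compound 3 (1.06 log units; beyond the scatter), a fall estimated to lie beyond the scatter. For compound 3 the estimate is 2500 nM, with an expected range of 600 nM to 12000 nM.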

Compound 3, solubility: < 1000 nM
Compound 3 gave a limit, no number (the forecaster's own chance of this, stated with the estimate: 35%); middle value at least 2.5-fold (0.39 log units) from the limit.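

For the compounds shown here, the one earlier step put 3-(hydroxymethyl)phenyl in place of piperidin-1-yl, so it could not separate the phenyl from the hydroxymethyl. Going from 3-(hydroxymethyl)phenyl to phenyl in this assay gives an at least 29-fold lower number from compound 2 to compound 3 (1.46 log units; beyond the scatter), so in this pair the measurable number goes with the hydroxymethyl, and phenyl alone does not keep it. Compound 3 gives a limit, not a number, and its step from compound 1 cannot be read, as both sit at the same limit: the limit of < 1000 nM in this assay, at which 2 of the 3 values shown sit.

As far as these compounds go, how far the true value of compound 3 lies from that limit stays open, and with it the full size of the fall. Also open, from the compounds shown here alone, is whether an amine, a carboxylic acid or a longer chain ending in a hydroxyl on the same aromatic carbon would give a number like that of compound 2.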